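The compounds below may be only part of what the source reports. "The series", "measured", "known", "first", "only" and "open" are said of these compounds alone.

Among the compounds with values here, compound 2 `C[C@H](NC(=O)CN(c1ncnc2c1ncn2C1CCCCO1)C1CC1)C(=O)OCc1ccccc1` stands at the top of the two numbers so far in a functional assay on the whole organism (Tail, strain ICR) with Mus musculus as the target, in the tail flick test, with a stated time of 30 min, at a dose of 25 umol/kg by the oral route; a lower number here means a weaker effect, a higher number a stronger effect of the compound at the dose given: compound 2 gives 55.9%, whereas compound 1 `O=C(CN(c1ncnc2c1ncn2C1CCCCO1)C1CC1)N[C@@H](CO)C(=O)OCc1ccccc1` gives 27.8%. Within the data shown here, the one measured step, a number 28.1 percentage points higher from compound 1 to compound 2 (beyond the scatter), came from hydrogen in place of hydroxy on a saturated chain carbon, two bonds along the chain from an amide-type nitrogen and a carbonyl carbon. Compound 3 `CC(C)C[C@H](NC(=O)CN(c1ncnc2c1ncn2C1CCCCO1)C1CC1)C(=O)OCc1ccccc1` differs from compound 2 by isopropyl in place of hydrogen on a saturated chain carbon, two bonds along the chain from an amide-type nitrogen and a carbonyl carbon. Among the measured compounds shown here, this change enlarges a carbon group at that same chain carbon, while the measured step removed a hydroxy there; no measured pair shows what added carbon at this carbon does, so the step from compound 1 to compound 2 bears on it only loosely. The expectation for this assay is therefore a step of about a number 0.9 percentage points lower from compound 2 to compound 3 (within the scatter), which is not expected to go beyond the scatter in either direction. Compound 3 is estimated at 55%, with a range from 30% to 80%.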

Compound 3, a percentage reported as activity, at one dose (the size of the read-out at that dose, not a potency): 26.2%
Compound 3: middle estimate off by 28.8 percentage points, on the high side; measured number below the stated range.
By their numbers in this assay, from the lowest: compounds 3 and 1 (each within the scatter of the next); then compound 2.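

At this saturated chain carbon, two bonds along the chain from an amide-type nitrogen and a carbonyl carbon, enlarging the carbon group also lowers the read-out in this assay: isopropyl in place of hydrogen gives a number 29.7 percentage points lower from compound 2 to compound 3 (beyond the scatter) and so runs against the expectation of no clear change. Hydroxy and isopropyl, which have little in common as groups, do not separate here, with isopropyl in place of hydroxy giving a number 1.6 percentage points lower from compound 1 to compound 3 (within the scatter) and no order between the two compounds. Among these three compounds, the methyl side chain of compound 2 alone stands apart, with steps beyond the scatter to both others.

Going by these compounds, an ethyl group or a straight butyl chain at this carbon would show how the number runs between methyl and isobutyl, and an amine on the side chain remains open too. The data shown offer no evidence on why these numbers differ.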